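The source may report more compounds than this note shows. Statements on the series, on what has been measured and on what is new or still open speak of the compounds shown alone.

Compound 1 `O=c1n(Cc2cc3cnccc3n2CCCCO)c2cnccc2n1C1CC1` and compound 2 `N#CCCCn1c(Cn2c(=O)n(-c3ccc(C(=O)NC4CC4)cc3)c3ccncc32)cc2cc(Cl)ccc21` have both been run in an ADME assay on HeLa cells (Homo sapiens) for cytotoxicity, read by ATP content, with a stated time of 3 days; on this read-out lower numbers stand for higher toxicity in this test and higher numbers for lower toxicity in this test. For compound 1 the read-out is a limit of the measurement rather than a number: compound 1 gives > 100000 nM. For compound 2 the read-out is likewise a limit: compound 2 gives > 50000 nM. The two limits are the limit of > 100000 nM in this assay, at which 1 of the 2 values shown sits, and (the limit of > 50000 nM in this assay, at which 1 of the 2 values shown sits). Compound 2 therefore stands with no toxicity resolved within the range of this assay, as does compound 1.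

Compound 3 `COc1ccc(-n2c(=O)n(Cc3cc4cc(Cl)ccc4n3CCCC#N)c3cnccc32)c(C)c1` is not yet measured. It differs from compound 2 by 4-methoxy-2-methylphenyl in place of 4-(cyclopropylcarbamoyl)phenyl on an aromatic nitrogen. Going by the values given here, no step between measured compounds is available from which a size for this change could be read. The expectation for this assay is no step beyond the scatter, with compound 3 staying at or near the limit. For compound 3 the expected value in this assay is estimated at 60000 nM, with a range from 20000 nM to 200000 nM. The expected step from compound 2 to compound 3 is a step that the limit leaves unreadable from compound 2 to compound 3.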

Compound 3, half-maximal cytotoxic concentration: > 50000 nM
Compound 3 ended at the assay's limit; the forecaster's own chance of this, stated with the estimate: 70%; the middle value is on the limit's open side.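

Compound 2 and compound 3 both rest on a limit in this assay, so no step can be read between them. The compounds shown leave open whether 4-methoxy-2-methylphenyl in place of 4-(cyclopropylcarbamoyl)phenyl on an aromatic nitrogen changes toxicity in this test at all.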